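The compounds below may be only part of what the source reports. "The series", "measured", "known", "first", "only" and "open" are said of these compounds alone.

Compound 1 `COCCN1C(N)=NC(N)=NC12CCN(C(=O)c1cccn1C)CC2` and compound 2 `CCS(=O)(=O)N1CCC2(CC1)N=C(N)N=C(N)N2CCOC` share one core. In an ADME assay on MDCK cells (Canis lupus familiaris) for cytotoxicity, read by microscopy, with a stated time of 6 days (on this read-out higher numbers stand for lower toxicity in this test and lower numbers for higher toxicity in this test), compound 1 gives > 100000 nM, a limit of the assay rather than a number. In this assay compound 2 likewise gives > 100000 nM, which is also a limit. The step that the two limits leave unreadable from compound 1 to compound 2 therefore cannot be read, since both values sit at the same limit (the limit of > 100000 nM in this assay, at which 2 of the 2 values shown sit). Compound 3 `COCCN1C(N)=NC(N)=NC12CCN(S(=O)(=O)c1ccccc1)CC2` differs from compound 2 by phenyl in place of ethyl on a sulfonyl sulfur. No measured step bears on an exchange on a sulfonyl sulfur, and the only step shown is unreadable, so nothing beyond the scatter is expected. Compound 3 is expected to give 100000 nM, between 40000 nM and 250000 nM, most likely again as a limit. The expected step is a number no higher from compound 2 to compound 3 (the limit leaves the size open).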

Compound 3, minimum cytotoxic concentration: > 100000 nM
Compound 3 ended at the assay's limit; the forecaster's own chance of this, stated with the estimate: 80%; the middle value sits exactly at the limit.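

No new step can be read between compound 2 and compound 3, because both values are limits and not numbers: the limit of > 100000 nM in this assay, at which 3 of the 3 values shown sit. In this assay the compounds shown leave open whether any exchange on the shared core changes the minimum cytotoxic concentration.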